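Swapping the benzyl halogen for methyl in a sulfonylguanidine series

The source may report more compounds than this note shows. Statements on the series, on what has been measured and on what is new or still open speak of the compounds shown alone.

Compound 1, `Cc1cc(-c2ccccc2)n(/C(N)=N/S(=O)(=O)c2cc(C)c(Cl)cc2SCc2cccc3ccccc23)n1`, gives 7000 nM in a functional assay on HCT-116 cells (Homo sapiens) for cytotoxicity, read by MTT assay, with a stated time of 72 h; on this read-out higher numbers stand for weaker inhibition and lower numbers for stronger inhibition.
Compound 2, `Cc1ccc(CSc2cc(Cl)c(C)cc2S(=O)(=O)/N=C(\N)n2nccc2-c2ccccc2)cc1`, gives 14000 nM in this assay.
Compound 3, `Cc1cc(-c2ccccc2)n(/C(N)=N/S(=O)(=O)c2cc(C)c(Cl)cc2SCc2ccc(Cl)cc2)n1`, gives 7000 nM in this assay.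

Compound 3 stands level with compound 1 at the digits shown, and together they hold the lowest numbers of the three; compound 2 is furthest from compound 3, yet that gap lies within the scatter. For the measured compounds named here, the one measured step, no change at the digits printed from compound 1 to compound 3 (within the scatter), shows that exchanging the group on the saturated chain carbon bound to sulfur left the number unchanged. Compound 4, `Cc1ccc(CSc2cc(Cl)c(C)cc2S(=O)(=O)/N=C(\N)n2nc(C)cc2-c2ccccc2)cc1`, is not yet measured. It differs from compound 3 in methyl in place of chloro on an aromatic carbon. Going by the values given here, no measured step isolates this exchange. Compound 2 carries the same 4-methylbenzyl group as compound 4 but lacks the methyl on the shared core, so its value speaks only loosely for the present case. Given no change at the digits printed from compound 1 to compound 3 (within the scatter), the remote end of the benzyl group appears tolerant of change, so compound 4 is expected to show a 1.3-fold higher number from compound 3 to compound 4 (0.11 log units; within the scatter), essentially none beyond the scatter. Compound 4 is therefore estimated at 9000 nM, within 4000 nM to 20000 nM.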

Compound 4, half-maximal inhibitory concentration: 28000 nM
The estimate for compound 4 lay 3.1-fold (0.49 log units) below the measured number, outside the stated range (above it).
By their numbers in this assay, from the lowest: compounds 1, 3, 2 and 4 (each within the scatter of the next, the first and the last beyond it).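

The benzyl group now proves sensitive to what it carries in this assay: chloro to methyl gives a 4.0-fold higher number from compound 3 to compound 4 (0.60 log units; beyond the scatter) and stands beyond the scatter, as does naphthalen-1-yl to 4-methylphenyl with a 4.0-fold higher number from compound 1 to compound 4 (0.60 log units; beyond the scatter), whereas the earlier exchange of naphthalen-1-yl for 4-chlorophenyl gave no change at the digits printed from compound 1 to compound 3 (within the scatter) and separated nothing. The added methyl on the shared core, by contrast, gives a 2.0-fold higher number from compound 2 to compound 4 (0.30 log units; within the scatter) and stays within the scatter, so this step alone cannot show that the methyl matters. Nothing at hand says why methyl and chloro part at this position.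

Going by these compounds, what a methoxy group or a bromine atom would give at this position remains open. So does whether chloro would also give the lower number on the core without the added methyl.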